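The compounds below may be only part of what the source reports. "The series", "measured", "known", "first", "only" and "open" are said of these compounds alone.

Compound 1, `O/N=C(\CCN1CCN(c2ccccn2)CC1)c1ccccc1`, gives 70% in a functional assay on HEK293 cells with D(4) dopamine receptor (Homo sapiens) as the target, read by FLIPR; on this read-out lower numbers stand for smaller maximal responses and higher numbers for larger maximal responses.
Compound 2, `O/N=C(\CCN1CCN(c2ccccn2)CC1)c1ccccc1Cl`, gives 74% in this assay.
Compound 3, `N#Cc1cccc(/C(CCN2CCN(c3ccccn3)CC2)=N/O)c1`, gives 48% in this assay.

Among these three, compound 3 stands lowest in this assay: the nearest number is that of compound 1, the furthest that of compound 2, and both gaps lie beyond the scatter. Compound 4, `O/N=C(\CCN1CCN(c2ccccn2)CC1)c1ccc(Cl)cc1`, has not yet been measured in this assay. It differs from compound 3 in one place: 4-chlorophenyl in place of 3-cyanophenyl on a carbon with a double bond to nitrogen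

Among the measured compounds shown here, two measured steps bear on this change. The step of a number 26 percentage points lower from compound 2 to compound 3 (beyond the scatter) shows what replacing a chlorophenyl with the 3-cyanophenyl did, and the step of a number 22 percentage points lower from compound 1 to compound 3 (beyond the scatter) shows what putting the cyano group onto the aromatic carbon did. The step of a number 4 percentage points higher from compound 1 to compound 2 (within the scatter) shows that a chloro group on an aromatic carbon left the response essentially where it was. Compound 4 therefore is expected to move back upward, because the step of a number 26 percentage points lower from compound 2 to compound 3 (beyond the scatter) ran downward and compound 4 has a chlorophenyl again. The expected step is a number 20 percentage points higher from compound 3 to compound 4 (beyond the scatter), although the 4-chlorophenyl is not the same group as the 2-chlorophenyl of compound 2, so the range is wide. For compound 4 the estimate in this assay is 68%, with a range from 50% to 85%.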

Compound 4, largest response reached (reported as efficacy), in percent of the reference or control that the assay uses: 46%
Beside the measured number, compound 4's estimate is 22 percentage points above it; the whole stated range lies above it.
By their numbers in this assay, from the lowest: compounds 4 and 3 (each within the scatter of the next); then compounds 1 and 2 (each within the scatter of the next).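

Compound 4 shows that chloro in place of hydrogen on an aromatic carbon is not a neutral change in every case: in this assay the 2-chlorophenyl of compound 2 left the response within the scatter (a number 4 percentage points higher from compound 1 to compound 2 (within the scatter)), whereas the 4-chlorophenyl gave a number 24 percentage points lower from compound 1 to compound 4 (beyond the scatter). The two chlorophenyl groups are therefore not interchangeable at this carbon with a double bond to nitrogen, as a number 28 percentage points lower from compound 2 to compound 4 (beyond the scatter) makes plain, so a chlorophenyl as such does not restore the response. The 4-chlorophenyl instead matches the 3-cyanophenyl, with a number 2 percentage points lower from compound 3 to compound 4 (within the scatter), and nothing shown gives a reason for these differences.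

The compounds shown leave open whether the response follows the identity of the group on the aromatic ring or where on the ring it sits, since the cyano group appears only in the 3-cyanophenyl and the chloro group in just two arrangements. They also leave open how a methoxy group, an amine or a carboxylic acid on that ring would compare with the chloro and cyano groups in this assay.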